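A few compounds are considered here, and "the series" means these few. Any claim that something is new, unique, unknown or untested is made for them only; others in the source may bear on it.

Working notes on the series in a functional assay on K562 cells (Homo sapiens) for antiproliferative activity; a higher number here means a weaker inhibitor, a lower number a stronger inhibitor. Compound 1 `C=C(Br)C(=O)Nc1ccc2[nH]c(C(=O)O)cc2c1` gives 5600 nM. Compound 2 `C=C1CC(COc2cc(C(=O)O)n(C)n2)(c2ccc(Cl)cc2)OC1=O` reaches only the limit of the assay, > 10000 nM. Compound 3 `C=C1CC(COc2cc(C(=O)O)n(C)n2)(c2ccccc2)OC1=O` likewise stops at the limit, > 10000 nM. Compound 3 thus stands at the limit of this assay and not at a number; the limit of > 10000 nM in this assay, at which 2 of the 3 values shown sit, marks where it sits. For the measured compounds named here, the one step among the measured compounds that stays within the shared core of compound 3, a step that the two limits leave unreadable from compound 2 to compound 3, cannot be sized, since the limit of > 10000 nM in this assay, at which 2 of the 3 values shown sit, covers both of its ends.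

Compound 4 `C=C1CC(C)(COc2cc(C(=O)O)n(C)n2)OC1=O` differs from compound 3 by methyl in place of phenyl on a saturated ring carbon. Going by the values given here, no measured step in this assay bears directly on that change, and the only step inside the core, from compound 2 to compound 3, yields no readable size. The expectation for compound 4 is that it remains at the limit, with a step that the limit leaves unreadable from compound 3 to compound 4 expected to stay within the scatter. Compound 4 is estimated at 20000 nM, within 8000 nM to 60000 nM, and is expected most likely to be reported again only as a limit.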

Compound 4, half-maximal inhibitory concentration: > 10000 nM
Compound 4: only a limit was reported; the forecaster's own chance of this, stated with the estimate: 80%; the middle value lies beyond the limit too.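

Compound 4 gives > 10000 nM, a limit and not a number, so the steps joining compound 2, compound 3 and compound 4 cannot be read. The compounds shown leave open whether any group on that saturated ring carbon of the shared core yields a numerical value.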